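The compounds below may be only part of what the source reports. "The series", "measured", "known", "first", "only" and "open" are said of these compounds alone.

Compound 1 `Cc1ccccc1-n1nncc1CN1C(=O)C2(C(C#N)=C(N)Oc3c2c2nc4ccccc4nc2c2ccccc32)c2ccccc21`: in a functional assay on MCF7 cells (Homo sapiens) for antiproliferative activity, read by MTT assay, with a stated time of 48 h (on this read-out lower numbers stand for stronger inhibition and higher numbers for weaker inhibition), compound 1 gives > 50000 nM, a limit of the assay.
Compound 2 `N#CC1=C(N)Oc2c(c3nc4ccccc4nc3c3ccccc23)C12C(=O)N(Cc1cnnn1-c1ccccc1Cl)c1ccccc12`: compound 2 gives > 50000 nM, likewise a limit.
Compound 3 `N#CC1=C(N)Oc2c(c3nc4ccccc4nc3c3ccccc23)C12C(=O)N(Cc1cnnn1-c1cccc(Cl)c1)c1ccccc12`: compound 3 gives 43600 nM.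

Compound 3 thus holds the only number shown; the two other values sit at the limit of > 50000 nM in this assay, at which 2 of the 3 values shown sit. The step of an at least 1.1-fold lower number from compound 1 to compound 3 (0.05 log units; that floor lies within the scatter) and the step of an at least 1.1-fold lower number from compound 2 to compound 3 (0.05 log units; that floor lies within the scatter) are read from that limit, and the step that the two limits leave unreadable from compound 1 to compound 2 cannot be read at all. Compound 4 `COc1ccc(-n2nncc2CN2C(=O)C3(C(C#N)=C(N)Oc4c3c3nc5ccccc5nc3c3ccccc43)c3ccccc32)cc1` carries the change (4-methoxyphenyl in place of 3-chlorophenyl on an aromatic nitrogen). Going by the values given here, no measured step involves a methoxy group, and all three compounds sit at or near the limit, so no step beyond the scatter is expected. Compound 4 is therefore estimated at 48000 nM, between 20000 nM and 100000 nM, an expected step of a 1.1-fold higher number from compound 3 to compound 4 (0.04 log units; within the scatter).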

Compound 4, half-maximal inhibitory concentration: > 50000 nM
Compound 4 was reported as a limit (the forecaster's own chance of this, stated with the estimate: 55%); middle value at least 1.0-fold (0.01 log units) from the limit.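

With 4-methoxyphenyl on the aromatic nitrogen, the first oxygen-bearing group shown at this position, the result is an at least 1.1-fold higher number from compound 3 to compound 4 (0.05 log units; that floor lies within the scatter), so this change brings no readable gain. The steps to compound 4 from compound 1 and from compound 2 cannot be read: both ends are limits. Most of the series now rests at a single limit: the limit of > 50000 nM in this assay, at which 3 of the 4 values shown sit.

Going by these compounds, whether an unsubstituted phenyl, or an amine or a carboxylic acid on this phenyl ring, would give a value clear of that limit stays open.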